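The source may hold more compounds than are shown below. What is called first, only, known or untested is meant among the compounds shown, and "the series" means these compounds.

Compound 1 `Cc1noc(C)c1-c1ccc2c(c1)C(c1ccccc1)N(Cc1nnc(-c3ccccc3)o1)C(=O)N2C` gives 34.7% in a functional assay on HepG2 cells (Homo sapiens) for inhibition, read by MTT assay, with a stated time of 48 h, tested at 2 uM; a higher number here means more inhibition at the concentration tested (going by the name of the read-out), a lower number less inhibition.
Compound 2 `Cc1noc(C)c1-c1ccc2c(c1)C(c1ccccc1)N(Cc1ncc(-c3ccccc3)o1)C(=O)N2C` gives 50.6% in this assay.
Compound 3 `Cc1nc(-c2ccccc2)sc1CN1C(=O)N(C)c2ccc(-c3c(C)noc3C)cc2C1c1ccccc1` gives 29.2% in this assay.

Compound 3 has the lowest of the three numbers, but a number 5.5 percentage points lower from compound 1 to compound 3 (within the scatter) lies within the scatter, while a number 21.4 percentage points lower from compound 2 to compound 3 (beyond the scatter) lies beyond it. Compound 4 `Cc1nc(-c2ccc(F)cc2)sc1CN1C(=O)N(C)c2ccc(-c3c(C)noc3C)cc2C1c1ccccc1` differs from compound 3 by fluoro in place of hydrogen on an aromatic carbon. Among the compounds with values here, none of the measured steps touches this change: a number 15.9 percentage points higher from compound 1 to compound 2 (beyond the scatter), a number 5.5 percentage points lower from compound 1 to compound 3 (within the scatter) and a number 21.4 percentage points lower from compound 2 to compound 3 (beyond the scatter) all exchange the whole ring attached to the saturated chain carbon, not a substituent on a phenyl. Within the data shown here, with no step bearing on it, the change is expected to bring no shift beyond the scatter in this assay, so a number 0.8 percentage points higher from compound 3 to compound 4 (within the scatter) is the estimated step. Compound 4 is therefore expected to give about 30%, between 16% and 44%.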

Compound 4, a percentage reported as inhibition, at one concentration (the size of the read-out at that concentration, not a potency): 26.4%
For compound 4 the middle estimate is 3.6 percentage points above the measured one; the range from low to high includes it.
By their numbers in this assay, from the lowest: compounds 4, 3 and 1 (each within the scatter of the next); then compound 2.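

Unlike the earlier steps, which exchange the whole ring on the saturated chain carbon, this one alters only a substituent on the phenyl of the 4-methyl-2-phenyl-1,3-thiazol-5-yl group. In this assay phenyl to 4-fluorophenyl gives a number 2.8 percentage points lower from compound 3 to compound 4 (within the scatter), so fluoro at this position leaves the number within the scatter. Nothing available explains this result.

On these data alone, whether an amine, a methoxy group or a carboxylic acid at this position would move the number remains open. So does whether fluoro would have a similarly small effect on the phenyl of the 5-phenyl-1,3-oxazol-2-yl group in compound 2.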